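The compounds below may be only part of what the source reports. "The series", "measured", "known", "first", "only" and "open" are said of these compounds alone.

Measured compounds:
- compound 1, `CSc1cc(-c2cnc(N)c(OC(F)F)n2)nc(N2C[C@@H]3C[C@H]2CO3)n1`: 45 nM
- compound 2, `Nc1ncc(-c2cc([C@H]3CCCO3)nc(N3C[C@@H]4C[C@H]3CO4)n2)nc1OC(F)F`: 202 nM
- compound 3, `Nc1ncc(-c2cc(N3C[C@@H]4C[C@H]3CO4)nc(N3CC4CC3C4)n2)nc1OC(F)F`: 7 nM

In an assay on Sf21 cells for inhibition of mitogen-activated protein kinase kinase kinase 13 (Homo sapiens), read by HTRF, with a stated time of 1.5 h (on this read-out higher numbers stand for weaker inhibition and lower numbers for stronger inhibition), compound 2 stands highest of the three numbers; its nearest neighbour is compound 1 and its furthest is compound 3, both steps beyond the scatter. The unmeasured compound 4, `Nc1ncc(-c2cc(N3CC4CC3C4)nc(N3C[C@@H]4C[C@H]3CO4)n2)nc1OC(F)F`, differs from compound 2 in one place: a group of 6 heavy atoms (5 carbon, 1 nitrogen; one four-membered non-aromatic ring of carbon only, one five-membered non-aromatic ring with 1 hetero atom) in place of a group of 5 heavy atoms (4 carbon, 1 oxygen; one five-membered non-aromatic ring with 1 hetero atom), on an aromatic carbon.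

For the measured compounds named here, only one measured step touches this site: a 4.5-fold higher number from compound 1 to compound 2 (0.65 log units; beyond the scatter). Putting oxolan-2-yl onto that carbon raised the number; taking it off again in favour of a different group is therefore expected to move back toward or below compound 1. Going by the values given here, compound 3 carries the same entering group, though elsewhere on the shared core, and gives 7 nM; no step to compound 4 can be drawn from it. A modest drop is expected, a 6.7-fold lower number from compound 2 to compound 4 (0.83 log units; beyond the scatter), in this assay.

For compound 4 the estimate in this assay is 30 nM, range 8 nM to 120 nM.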

Compound 4, half-maximal inhibitory concentration: 35 nM
Compound 4: middle estimate off by 1.2-fold (0.07 log units), on the low side, within the range that was stated.
By their numbers in this assay, from the lowest: compound 3; then compounds 4 and 1 (each within the scatter of the next); then compound 2.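

In this assay the aromatic carbon next to the ring nitrogen now carries a second replacement for oxolan-2-yl, and the step of a 5.8-fold lower number from compound 2 to compound 4 (0.76 log units; beyond the scatter) lies beyond the scatter. Oxolan-2-yl therefore stands as the group with the high number among the three groups compared here at this carbon, while the site itself also tolerates groups that give much lower numbers. The further step of a 1.3-fold lower number from compound 1 to compound 4 (0.11 log units; within the scatter) lies within the scatter, so methylsulfanyl, with no ring, and the entering group, with 6 heavy atoms and two rings, cannot be told apart in this assay and neither group size nor ring count orders these compounds; nothing available accounts for either step.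

Open, as far as these compounds go, is how an open-chain amine such as dimethylamino, or a single-ring amine such as pyrrolidine, would read at this carbon, and with it whether the four-membered carbon ring of the entering group contributes to the number. Also open, from the compounds shown here alone, is whether a methoxy group or a longer alkyl chain at this carbon would stay with compound 1 and compound 4 or move toward compound 2.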